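Working notes on compounds 1 to 4

The source may hold more compounds than are shown below. What is called first, only, known or untested is meant among the compounds shown, and "the series" means these compounds.

compound 1: `O=C(CCCl)Nc1ccc(S(=O)(=O)Oc2ccccc2I)cc1` — 14000 nM
compound 2: `O=C(CCCCl)Nc1ccc(S(=O)(=O)Oc2ccccc2I)cc1` — 9100 nM
compound 3: `CCCNC(=O)Nc1ccc(S(=O)(=O)Oc2ccccc2I)cc1` — 6800 nM

All three numbers come from a functional assay on HT-29 cells (Homo sapiens) for antiproliferative activity, read by sulforhodamine B assay, with a stated time of 48 h; on this read-out lower numbers stand for stronger inhibition and higher numbers for weaker inhibition. On them compound 3 stands at the lowest number: the step of a 2.1-fold lower number from compound 1 to compound 3 (0.31 log units; beyond the scatter) lies beyond the scatter, whereas the step of a 1.3-fold lower number from compound 2 to compound 3 (0.13 log units; within the scatter) and the step of a 1.5-fold lower number from compound 1 to compound 2 (0.19 log units; within the scatter) both stay within it, so compound 2 and compound 3 cannot be ordered.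

Compound 4 is `O=C(Nc1ccc(S(=O)(=O)Oc2ccccc2I)cc1)NC1CC1`, not yet measured in this assay. Its change from compound 3 is cyclopropyl in place of propyl on an amide-type nitrogen. Going by the values given here, no measured step bears on this position: the two steps into compound 3 exchange the group on the carbonyl carbon, and none of compounds 1 to 3 varies the group on the amide-type nitrogen. The steps that are known are small to modest, and nothing among them points in either direction for this exchange. The step of a 1.0-fold lower number from compound 3 to compound 4 (0.02 log units; within the scatter) is therefore expected to stay within the scatter, with the range widened for the missing precedent. Compound 4 is estimated at 6500 nM, between 2500 nM and 17000 nM.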

Compound 4, half-maximal inhibitory concentration: 14000 nM
For compound 4 the middle estimate is 2.2-fold (0.33 log units) below the measured one; the measured number falls inside the stated range.
By their numbers in this assay, from the lowest: compounds 3, 2, 1 and 4 (each within the scatter of the next, the first and the last beyond it).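

In this assay, the amide-type nitrogen proves sensitive to the group it carries: cyclopropyl in place of propyl gives a 2.1-fold higher number from compound 3 to compound 4 (0.31 log units; beyond the scatter), the first step seen at this position. On the carbonyl carbon, cyclopropylamino does not separate from the chlorinated chains, with a 1.5-fold higher number from compound 2 to compound 4 (0.19 log units; within the scatter) and no change at the digits printed from compound 1 to compound 4 (within the scatter), so the advantage of the propylamino group over 2-chloroethyl is lost once propyl gives way to cyclopropyl. No measurement shown here explains the step at the nitrogen.

With only propyl and cyclopropyl on this nitrogen, one exchange cannot tell whether the ring or some other difference between the two groups governs the step. Isopropyl, butyl and cyclobutyl remain open here, as does a terminal amine or carboxylic acid on the propyl chain.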